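Swapping Nitro for Ethoxy on an Inactive Triazole Pair

The source may report more compounds than this note shows. Statements on the series, on what has been measured and on what is new or still open speak of the compounds shown alone.

Measured compounds:
compound 1, `COc1cc(-n2ncnc2-c2cccc([N+](=O)[O-])c2)cc(OC)c1OC`: > 10000 nM
compound 2, `COc1cc(-c2ncnn2-c2ccc(F)cc2)cc(OC)c1OC`: > 10000 nM

Both values come from a functional assay on HeLa cells (Homo sapiens) for antiproliferative activity, read by MTT assay, with a stated time of 72 h; on this read-out higher numbers stand for weaker inhibition and lower numbers for stronger inhibition. For compound 1 the value > 10000 nM is a limit of the assay, not a number. For compound 2 the value > 10000 nM is likewise a limit. Compound 1 therefore stands at the limit of > 10000 nM in this assay, at which 2 of the 2 values shown sit, and the second value shows the same: neither compound reached a measurable half-maximal inhibitory concentration, so no ranking between them can be drawn.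

The unmeasured compound 3, `CCOc1cccc(-c2ncnn2-c2cc(OC)c(OC)c(OC)c2)c1`, keeps the shared core of compound 1 and changes one group: ethoxy in place of nitro on an aromatic carbon.

Among the compounds with values here, no measured step is available to judge how this change acts, and both measured values are limits, so nothing in the data suggests that the change would bring the value into the measurable range. The expected step is a step that the limit leaves unreadable from compound 1 to compound 3, that is, none beyond the scatter. Compound 3 is accordingly estimated to give 15000 nM in this assay, with a range from 4000 nM to 60000 nM, most likely reported again only as a limit.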

Compound 3, half-maximal inhibitory concentration: > 10000 nM
Compound 3: a limit, no number; the forecaster's own chance of this, stated with the estimate: 70%; the middle value is on the limit's open side.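

In this assay compound 3 gives > 10000 nM and this is a limit, not a number. Within the data shown here, compound 1 also sits at a limit, so no step for ethoxy in place of nitro can be read between compound 1 and compound 3: the limit of > 10000 nM in this assay, at which 3 of the 3 values shown sit.

The compounds shown leave open whether either group allows a measurable half-maximal inhibitory concentration.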